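The source may report more compounds than this note shows. Statements on the series, on what has been measured and on what is new or still open speak of the compounds shown alone.

Working notes on the series. All compounds share one bicyclic sulfonamide core. Compound 1 `CC1(C)[C@@H]2CC[C@@]1(CS(=O)(=O)N1CCN(c3ncccc3C(F)(F)F)CC1)C(=O)C2` carries a ketone on that core; in a functional assay on CHO-K1 cells for antagonist activity at C-X-C chemokine receptor type 3 (Homo sapiens), read by FLIPR and calcium flux (a higher number here means a weaker inhibitor, a lower number a stronger inhibitor), compound 1 gives only a limit, > 31600 nM, and no number. Compound 2 `CC1(C)[C@@H]2CC[C@@]1(CS(=O)(=O)N1CCN(c3ccc(C(F)(F)F)cn3)CC1)C(O)C2` carries a hydroxy on a saturated ring carbon instead and gives 158 nM in this assay. Compound 3 `CC1(O)C[C@H]2CC[C@]1(CS(=O)(=O)N1CCN(c3ccc(C(F)(F)F)cn3)CC1)C2(C)C` has a methyl in place of hydrogen on that saturated ring carbon and gives 200 nM; the step of a 1.3-fold higher number from compound 2 to compound 3 (0.10 log units; within the scatter) shows nothing beyond the scatter. Compound 2 thus holds the lowest of the two numbers, with compound 3 the nearest and within the scatter. The third value, that of compound 1, is the limit of > 31600 nM in this assay, at which 1 of the 3 values shown sits.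

Compound 4 `CCNC(=O)NC1C[C@H]2CC[C@]1(CS(=O)(=O)N1CCN(c3ccc(C(F)(F)F)cn3)CC1)C2(C)C` differs from compound 2 by (ethylcarbamoyl)amino in place of hydroxy on a saturated ring carbon. Among the compounds with values here, no measured step covers a change of this kind: the one single-change step, from compound 2 to compound 3, concerns a methyl added at the same ring carbon and stayed within the scatter, while compound 1 differs from compound 2 in two places and yields only a limit. The entering group is the larger of the two as counted, and the outcome is open. A modest weakening, or no change beyond the scatter, is expected: a 1.6-fold higher number from compound 2 to compound 4 (0.20 log units; within the scatter). Compound 4 is estimated at 250 nM in this assay, within 60 nM to 1000 nM.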

Compound 4, half-maximal inhibitory concentration: 794 nM
Beside the measured number, compound 4's estimate is 3.2-fold (0.50 log units) below it; measured number inside the range.
By their numbers in this assay, from the lowest: compounds 2 and 3 (each within the scatter of the next); then compound 4. At a limit, above all of these: compound 1.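

At this saturated ring carbon, this assay now shows a change beyond the scatter (a 5.0-fold higher number from compound 2 to compound 4 (0.70 log units; beyond the scatter)) for (ethylcarbamoyl)amino in place of hydroxy, whereas the methyl change earlier stayed within it (a 1.3-fold higher number from compound 2 to compound 3 (0.10 log units; within the scatter)). The position therefore accepts this larger group with a modest loss, and compound 4 still gives a measured number and not a limit. The compounds shown give no cause for this step, since the larger group, its extra hydrogen-bond donor and the loss of the hydroxy all arrive together.

As far as these compounds go, whether a simple amine at this carbon, or an acetylamino group, would stay within the scatter of compound 2 remains open, as does whether a longer chain in place of the ethyl of compound 4 would move the number further. The ketone of compound 1 also stays unresolved, as compound 1 differs from compound 2 in two places and so cannot be read as a step at this position.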